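The source may report more compounds than this note shows. Statements on the series, on what has been measured and on what is new or still open speak of the compounds shown alone.

Measured in a functional assay on Capan-2 cells (Homo sapiens) for inhibition, read by MTT assay, with a stated time of 72 h; on this read-out higher numbers stand for weaker inhibition of growth and lower numbers for stronger inhibition of growth:
compound 1 `O=S(=O)(NCCNCc1ccc(-c2ccccc2)cc1)c1cc(C(F)(F)F)cc(C(F)(F)F)c1` gives 2400 nM
compound 2 `O=S(=O)(NCCCNCc1ccc(C(F)(F)F)cc1)c1cc(C(F)(F)F)cc(C(F)(F)F)c1` gives 2000 nM
compound 3 `O=S(=O)(NCCCNCc1ccc(-c2ccccc2)cc1)c1cc(C(F)(F)F)cc(C(F)(F)F)c1` gives 2200 nM

Compound 2 carries the lowest of the three numbers, but its gaps to compound 3 and to compound 1 both lie within the scatter, so no order among the three can be read. Compound 4 `COc1ccccc1CNCCCNS(=O)(=O)c1cc(C(F)(F)F)cc(C(F)(F)F)c1` differs from compound 2 by 2-methoxyphenyl in place of 4-(trifluoromethyl)phenyl on a saturated chain carbon bound to an amine nitrogen. For the measured compounds named here, no measured step covers this exchange. Going by the values given here, the only step available, a 1.1-fold higher number from compound 2 to compound 3 (0.04 log units; within the scatter), also alters the 4-(trifluoromethyl)benzyl portion of compound 2 and leaves the number within the scatter. Lacking any direct precedent, the expectation for compound 4 in this assay is a step of a 1.3-fold higher number from compound 2 to compound 4 (0.10 log units; within the scatter), not beyond the scatter. Compound 4 is therefore estimated at 2500 nM, range 1000 nM to 6500 nM.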

Compound 4, concentration for 50% growth inhibition: 6000 nM
For compound 4 the middle estimate is 2.4-fold (0.38 log units) below the measured one; low and high end bracket the measured number.
By their numbers in this assay, from the lowest: compounds 2, 3 and 1 (each within the scatter of the next); then compound 4.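

In this assay, the exchange on the saturated chain carbon bound to the amine nitrogen now moves the number beyond the scatter (a 3.0-fold higher number from compound 2 to compound 4 (0.48 log units; beyond the scatter)). The earlier exchange in this portion, a 1.1-fold higher number from compound 2 to compound 3 (0.04 log units; within the scatter), stayed within the scatter, so the aromatic groups here do not all behave alike. No measurement at hand explains this step. On these data alone, whether the step belongs to the entering methoxy group or to the departing trifluoromethyl remains open. Also open, as far as these compounds go, is where a hydroxyl or nitrile group on this phenyl ring would fall.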